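The compounds below may be only part of what the source reports. "The series", "measured", "known", "first", "only" and "open" are said of these compounds alone.

The measured compounds, each with its reading in a functional assay on cells (Homo sapiens) for cytotoxicity; a higher number here means a weaker inhibitor, a lower number a stronger inhibitor:

Compound 1, `CO/N=c1\[nH]cnc2c1[n+](C/C=C(\C)CC/C=C(/C)CCC=C(C)C)cn2C`, gives 736 nM.
Compound 2, `CC(C)=CCC/C(C)=C\CC/C(C)=C/C[n+]1cn(C)c2nc[nH]/c(=N\OCc3ccccc3)c21`, gives 6760 nM.
Compound 3, `CO/N=c1\[nH]cnc2c1[n+](C/C=C(\C)CC/C=C(\C)CC/C=C(\C)CCC=C(C)C)cn2CCC#N`, gives 3960 nM.

Compounds 1 and 2 differ in one place only: phenyl in place of hydrogen on a saturated chain carbon bound to an oxygen. That change produces a 9.2-fold higher number from compound 1 to compound 2 (0.96 log units; beyond the scatter), so in this pairing the phenyl on the chain carbon bound to oxygen goes together with a clearly weaker compound.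

Compound 3 carries the same core arrangement as compound 1 but with a longer chain on the charged ring and a nitrile-bearing chain on the other ring nitrogen; the difference between the two cores is not broken down here. Against compound 3, the yet unmeasured compound 4, `CC(C)=CCC/C(C)=C/CC/C(C)=C/CC/C(C)=C/C[n+]1cn(CCC#N)c2nc[nH]/c(=N\OCc3ccccc3)c21`, shows exactly the change already seen once: phenyl in place of hydrogen on a saturated chain carbon bound to an oxygen. The place is the same in both pairs, so this is the same change made on a different core, and it occurs twice among the four compounds.

For the measured compounds named here, with only one earlier instance to lean on, compound 4 is expected to land weaker than compound 3 by a step close to the one seen from compound 1 to compound 2, that is a 7.6-fold higher number from compound 3 to compound 4 (0.88 log units; beyond the scatter), because compound 2 gave 6760 nM where compound 1 gave 736 nM. The estimated reading for compound 4 in this assay is therefore 30000 nM, likely between 10000 nM and 100000 nM.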

Compound 4, half-maximal inhibitory concentration: 9460 nM
Compound 4: middle estimate off by 3.2-fold (0.50 log units), on the high side; the measured number lies below the stated range.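

In this assay the change from methoxy to benzyloxy gives a 2.4-fold higher number from compound 3 to compound 4 (0.38 log units; beyond the scatter) and so points the same way on the core of compound 3 as on the core of compound 1, towards a weaker compound. The size of the step does not carry over from one core to the other: the same change on two cores in this assay, a 9.2-fold higher number (0.96 log units; beyond the scatter) from compound 1 to compound 2 and a 2.4-fold higher number (0.38 log units; beyond the scatter) from compound 3 to compound 4, 3.8-fold (0.58 log units) apart, beyond the scatter of two such steps. These two pairs therefore show that the direction of the change held on both cores while its size did not, so the step on one core gave the direction but not a reliable size for the other; they do not show why the size differs, nor whether the same direction would appear on any further core.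

The cores of compound 1 and compound 3 differ in both the chain on the charged ring and the nitrile-bearing chain on the other ring nitrogen, so the compounds shown leave open which of these two differences goes with the smaller step. They also leave open how other groups in place of the phenyl would read in this assay, for example a pyridine ring, a carboxylic acid or a longer saturated chain on the carbon bound to the oxygen.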